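A Methoxy Group Enters the Anilino Ring

This account rests on a few compounds, and the source may have more. Where it says the series, first, only, none or still open, it means among the compounds named here.

For the measured compounds named here, compound 1 `Cc1nc(SCC(=O)Nc2nc(-c3ccc(Cl)cc3)cs2)n(Nc2ccccc2)c1C` is the only compound here with a number: in a functional assay on SW-620 cells (Homo sapiens) for antiproliferative activity, read by sulforhodamine B assay, with a stated time of 48 h (a higher number here means a weaker inhibitor of growth, a lower number a stronger inhibitor of growth), compound 1 gives 22900 nM. Compound 2 `Cc1ccc(Nn2c(SCC(=O)Nc3nc(-c4ccccc4)cs3)nc(C)c2C)cc1` reaches only the limit of this assay, > 100000 nM. That limit is the limit of > 100000 nM in this assay, at which 1 of the 2 values shown sits. Compound 3 `COc1ccc(Nn2c(SCC(=O)Nc3nc(-c4ccc(Cl)cc4)cs3)nc(C)c2C)cc1` differs from compound 1 by methoxy in place of hydrogen on an aromatic carbon. No measured pair shares this change, so its size cannot be read from the numbers shown; a modest weakening in this assay, somewhat beyond the usual scatter, is expected. Compound 3 is estimated at 40000 nM, between 15000 nM and 100000 nM. The expected step is a 1.7-fold higher number from compound 1 to compound 3 (0.24 log units; within the scatter).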

Compound 3, concentration for total growth inhibition: > 100000 nM
Compound 3: a limit, no number (the forecaster's own chance of this, stated with the estimate: 35%); middle value at least 2.5-fold (0.39 log units) away from the limit.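

In this assay, methoxy on the anilino ring, para to a large group, does not leave growth inhibition intact: the step is an at least 4.3-fold higher number from compound 1 to compound 3 (0.64 log units; beyond the scatter). As far as these compounds go, the reading for compound 3 is a limit and not a number, so the true size of this step stays unknown. Measurable activity in this series is thus lost with this one change, and the values now gather at one ceiling: the limit of > 100000 nM in this assay, at which 2 of the 3 values shown sit.

From the compounds shown here alone, whether fluorine or an amine in the same place would keep a measurable value remains open, as does the effect of methoxy elsewhere on this ring.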